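Chain terminus variation in the anilide series: compound 4

This account rests on a few compounds, and the source may have more. Where it says the series, first, only, none or still open, it means among the compounds named here.

Compound 1 `CCCCCCCCC(C)(C)C(=O)Nc1c(C)cc(C)c2c1OC(C)(C)C2` gives 140 nM in an assay for inhibition of acyl-CoA:cholesterol acyltransferase (Oryctolagus cuniculus), using microsomes; on this read-out lower numbers stand for stronger inhibition and higher numbers for weaker inhibition. Compound 2 `Cc1cc(C)c(NC(=O)C(C)(C)CCCCCCN2CCCCC2)c2c1CC(C)(C)O2` reaches only the limit of the assay, > 500 nM. Compound 3 `Cc1cc(C)c(NC(=O)C(C)(C)CCCc2ccc(CC(C)C)cc2)c2c1CC(C)(C)O2` gives 40 nM, the lowest of the two numbers shown, with compound 1 the nearest; the step of a 3.5-fold lower number from compound 1 to compound 3 (0.54 log units; beyond the scatter) is beyond the scatter, and the step of an at least 12-fold lower number from compound 2 to compound 3 (1.09 log units; beyond the scatter) is measured against the limit of > 500 nM in this assay, at which 1 of the 3 values shown sits, and is likewise large. The step of an at least 3.5-fold higher number from compound 1 to compound 2 (0.55 log units; beyond the scatter) points the other way, so the terminus of the chain clearly matters for this read-out.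

Compound 4 `Cc1cc(C)c(NC(=O)C(C)(C)CCCCCOc2ccc(Cl)cc2)c2c1CC(C)(C)O2` differs from compound 3 by 2-(4-chlorophenoxy)ethyl in place of 4-isobutylphenyl on a saturated chain carbon, four bonds along the chain from a carbonyl carbon. Going by the values given here, no measured step covers this exact exchange. Among the compounds with values here, the ring is kept, so the gain seen in a 3.5-fold lower number from compound 1 to compound 3 (0.54 log units; beyond the scatter) is not expected to be lost in full; the added oxygen in the chain and the chlorine on the ring have no counterpart among the measured compounds, and the amine in compound 2 is not a fair model for them. A small move toward a higher number, within or near the scatter, is expected, a 1.8-fold higher number from compound 3 to compound 4 (0.24 log units; within the scatter). Compound 4 is therefore estimated at 70 nM, with a range from 25 nM to 250 nM in this assay.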

Compound 4, half-maximal inhibitory concentration: 150 nM
Compound 4: the middle estimate sits 2.1-fold (0.33 log units) below what was measured; the measured number falls inside the stated range.
By their numbers in this assay, from the lowest: compound 3; then compounds 1 and 4 (each within the scatter of the next). At a limit, above all of these: compound 2.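

In this assay, a ring at the chain end does not by itself hold the lower number: with 2-(4-chlorophenoxy)ethyl in place of 4-isobutylphenyl, the change is a 3.8-fold higher number from compound 3 to compound 4 (0.57 log units; beyond the scatter), so these two ring-bearing termini are not interchangeable at this place. Against the plain alkyl terminus, the change is a 1.1-fold higher number from compound 1 to compound 4 (0.03 log units; within the scatter), so this ring-bearing terminus brings no measurable gain, and among the compounds shown the 4-isobutylphenyl terminus alone gives a number lower than the alkyl chain beyond the scatter. The step of an at least 3.3-fold lower number from compound 2 to compound 4 (0.52 log units; beyond the scatter) gives only a bound and not a size, as one end of it is a limit of the assay: the limit of > 500 nM in this assay, at which 1 of the 4 values shown sits.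

Which part of the exchange carries the rise remains open, as the ether oxygen, the chlorine and the loss of the isobutyl group all come together in a single step. A 4-chlorophenyl terminus without the ether oxygen, a phenoxy terminus without the chlorine, or a 4-isobutylphenoxy terminus would separate these contributions, and a carboxylic acid at the chain end would test a terminus of another kind.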